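The source may hold more compounds than are shown below. What is called first, only, known or untested is meant among the compounds shown, and "the series" means these compounds.

compound 1, `CC(Oc1ccccc1-c1ccncc1)C1=NCCN1`: < 0.3
compound 2, `CC(Oc1ccccc1-c1ccccc1O)C1=NCCN1`: < 0.3
compound 3, `Cc1ccccc1-c1ccccc1OC(C)C1=NCCN1`: < 0.3

These three compounds share one core and differ only in the group attached to a single aromatic carbon. In a functional assay on CHO cells for agonist activity at Alpha-2B adrenergic receptor (Homo sapiens) (a higher number here means a larger maximal response, a lower number a smaller maximal response), compound 1 reaches no number, only a limit, < 0.3. Compound 2 likewise sits at a limit, < 0.3. Compound 3 also gives only a limit, < 0.3, so its standing among the three is not a measured number but the shared (the limit of < 0.3 in this assay, at which 3 of the 3 values shown sit). For that reason the steps a step that the two limits leave unreadable from compound 1 to compound 2, a step that the two limits leave unreadable from compound 1 to compound 3 and a step that the two limits leave unreadable from compound 2 to compound 3 have no readable size or direction.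

Compound 4, `CC(Oc1ccccc1-c1cccs1)C1=NCCN1`, differs from compound 3 in one place: thiophen-2-yl in place of 2-methylphenyl on an aromatic carbon. Within the data shown here, since none of the measured steps has a readable size, no direction beyond the scatter is expected for a step that the limit leaves unreadable from compound 3 to compound 4, and the expectation rests on the shared limit alone. Compound 4 is therefore expected to give about 0.2, within a range from 0.05 to 0.45, most probably again reported only as a limit.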

Compound 4, intrinsic activity: the largest response reached, as a fraction of the reference agonist's: 0.6
Compound 4: middle estimate off by 0.40, on the low side, outside the stated range (above it).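

In this assay, among these compounds, this aromatic carbon now proves to be a place where the choice of group can carry the maximal response clear of the limit, which the earlier compounds could not show. Placing thiophen-2-yl here gives a number at least 0.30 higher from compound 3 to compound 4 (beyond the scatter), a number at least 0.30 higher from compound 2 to compound 4 (beyond the scatter) and a number at least 0.30 higher from compound 1 to compound 4 (beyond the scatter), so all three steps are beyond the scatter, whichever of the other groups it replaces. Compound 4, with its five-membered aromatic ring containing a sulfur atom, is the only one of the four that stands off the shared limit: the limit of < 0.3 in this assay, at which 3 of the 4 values shown sit.

The steps among compound 1, compound 2 and compound 3 still cannot be read. On these data alone, a single compound also cannot separate the effect of ring size from that of the sulfur atom, and what a furan-2-yl group or a simple amine would give on this carbon stays open.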